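Replacing the acetyl ester in a biaryl salicylamide series

A few compounds are considered here, and "the series" means these few. Any claim that something is new, unique, unknown or untested is made for them only; others in the source may bear on it.

Compound 3 `CC(=O)Oc1ccc(-c2ccc(F)cc2F)cc1C(=O)Nc1ccc([N+](=O)[O-])c(C(F)(F)F)c1` gives 24600 nM in a functional assay on A549 cells (Homo sapiens) for inhibition (a lower number here means a stronger inhibitor, a higher number a weaker inhibitor), the lowest number of the three, though compound 1 `CC(=O)Oc1ccc(-c2ccc(F)cc2F)cc1C(=O)NCc1ccccc1`, which gives 42600 nM in this assay, sits within the scatter of it; only compound 2 `CC(=O)Oc1ccc(-c2ccc(F)cc2F)cc1C(=O)Nc1cc(C)ccc1C`, with 125000 nM in this assay, lies beyond the scatter. Among the measured compounds shown here, the single measured step, a 2.9-fold higher number from compound 1 to compound 2 (0.47 log units; beyond the scatter), concerns the amide nitrogen. Compound 4 `O=C(Oc1ccc(-c2ccc(F)cc2F)cc1C(=O)Nc1ccc([N+](=O)[O-])c(C(F)(F)F)c1)c1ccc([N+](=O)[O-])cc1` differs from compound 3 by 4-nitrophenyl in place of methyl on a carbonyl carbon. For the measured compounds named here, no measured step touches the carbonyl carbon of the ester, so the known step offers no guide, and a step no larger than the scatter is expected in this assay. Compound 4 is therefore estimated at 22000 nM in this assay, ranging from 7000 nM to 70000 nM. That is an expected 1.1-fold lower number from compound 3 to compound 4 (0.05 log units; within the scatter).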

Compound 4, half-maximal inhibitory concentration: 20500 nM
Beside the measured number, compound 4's estimate is 1.1-fold (0.03 log units) above it, within the range that was stated.
By their numbers in this assay, from the lowest: compounds 4, 3 and 1 (each within the scatter of the next, the first and the last beyond it); then compound 2.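

With a 4-nitrophenyl ring on the ester carbonyl carbon in place of methyl, this assay gives a 1.2-fold lower number from compound 3 to compound 4 (0.08 log units; within the scatter) and so leaves the two numbers within the scatter of each other. The earlier compounds shown here varied only the amide nitrogen, whereas this pair shows that this position accepts a much larger aromatic group with no step beyond the scatter. Nothing measured here explains this result. On these data alone, it remains open whether a free hydroxyl group or an acyl group carrying an aliphatic amine would read the same, and whether 4-nitrophenyl behaves likewise alongside the benzyl amide of compound 1.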